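This account rests on a few compounds, and the source may have more. Where it says the series, first, only, none or still open, it means among the compounds named here.

Compound 2 `COc1cc(NC(=O)Nc2cc(Nc3ccc(F)c(Cl)c3)ncn2)cc(OC)c1` stands highest of the two compounds measured in a functional assay on NCI-H1581 cells (Homo sapiens) for inhibition, read by MTT assay, with a stated time of 48 h, tested at 10 uM; a higher number here means more inhibition at the concentration tested (going by the name of the read-out), a lower number less inhibition; in this assay compound 2 gives 53%. Among the measured compounds shown here, its only neighbour, compound 1 `COc1cc(NC(=O)Nc2cc(Nc3ccc(C)c(C)c3)ncn2)cc(OC)c1`, gives 20.1% in this assay, and the step of a number 32.9 percentage points higher from compound 1 to compound 2 (beyond the scatter) is the one measured change that bears on what follows. Compound 3 `COc1cc(NC(=O)Nc2cc(Nc3ccc(C)c(F)c3)ncn2)cc(OC)c1` differs from compound 2 by 3-fluoro-4-methylphenyl in place of 3-chloro-4-fluorophenyl on a nitrogen on an aromatic ring. As this change keeps one halogen but brings back a methyl resembling compound 1, a step part of the way back is expected, a number 17 percentage points lower from compound 2 to compound 3 (beyond the scatter), and compound 3 is estimated at 36%, between 16% and 56%.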

Compound 3, a percentage reported as inhibition, at one concentration (the size of the read-out at that concentration, not a potency): 38%
Beside the measured number, compound 3's estimate is 2 percentage points below it, within the range that was stated.
By their numbers in this assay, from the lowest: compound 1; then compound 3; then compound 2.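

In this assay, among the compounds shown here, the single change of fluoro in place of methyl on an aromatic carbon already gives a number 17.9 percentage points higher from compound 1 to compound 3 (beyond the scatter), so the rise at this position does not need the full 3-chloro-4-fluorophenyl group. That group still holds an edge, with 3-fluoro-4-methylphenyl in its place giving a number 15 percentage points lower from compound 2 to compound 3 (beyond the scatter), so the remaining methyl-for-halogen difference also counts here. No evidence given here accounts for either step. As far as these compounds go, how a nitrile or a morpholine on this phenyl ring would compare remains open, as does whether 3-chloro-4-fluorophenyl keeps its edge on another core.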